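A few compounds are considered here, and "the series" means these few. Any claim that something is new, unique, unknown or untested is made for them only; others in the source may bear on it.

Compound 1, `CCN(c1ccncc1)n1cccc1`, was tested in a functional assay on the whole organism with Mus musculus as the target; a lower number here means that less compound is needed, a higher number that more compound is needed for the effect. In this assay compound 1 reaches only the limit of the measurement, > 20 mg/kg. Compound 2, `CCCCN(c1ccncc1)n1cccc1`, carries ethyl in place of hydrogen on a saturated chain carbon, two bonds along the chain from a nitrogen on an aromatic ring. In this assay compound 2 likewise stops at the limit, > 20 mg/kg. The step that the two limits leave unreadable from compound 1 to compound 2 therefore cannot be sized. Compound 3, `CN(c1ccncc1)n1cccc1C=O`, rests on a different core; the difference between the two cores is not broken down here. In this assay compound 3 also gives only the limit, > 20 mg/kg. All three values sit at the limit of > 20 mg/kg in this assay, at which 3 of the 3 values shown sit.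

Compound 4, `CCCN(c1ccncc1)n1cccc1C=O`, is not yet measured and differs from compound 3 by ethyl in place of hydrogen on a saturated chain carbon bound to a nitrogen on an aromatic ring. Among the compounds with values here, this is the same kind of change as the one from compound 1 to compound 2, yet not the same: in the earlier pair the ethyl enters on a saturated chain carbon two bonds along the chain from a nitrogen on an aromatic ring, whereas here it enters on a saturated chain carbon bound to a nitrogen on an aromatic ring. The step from compound 1 to compound 2 gave no readable size, and compound 3 offers only a limit, so the expectation for compound 4 rests on thin ground. The step that the limit leaves unreadable from compound 3 to compound 4 is the author's estimate, set near zero because compound 1, compound 2 and compound 3 all sit at the limit of > 20 mg/kg in this assay, at which 3 of the 3 values shown sit. For compound 4 in this assay the author expects 30 mg/kg, with an estimated range from 8 mg/kg to 120 mg/kg, and regards a further limit as the most likely report.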

Compound 4, dose for half-maximal effect: > 20 mg/kg
Compound 4: only a limit was reported; the forecaster's own chance of this, stated with the estimate: 80%; the middle value lies beyond the limit too.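

In this assay compound 4 gives > 20 mg/kg, which is a limit and not a number. Compound 3 also stops at a limit, so no size can be read for the step between compound 3 and compound 4. The compounds shown leave open what dose gives the half-maximal effect for any of them, and how the changes among them affect that dose, because all of them rest at one limit: the limit of > 20 mg/kg in this assay, at which 4 of the 4 values shown sit.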